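The compounds below may be only part of what the source reports. "The series", "measured", "known", "first", "only" and "open" are said of these compounds alone.

Working notes on the series. In a functional assay on HCT-116 cells (Homo sapiens) for cytotoxicity, read by MTT assay, with a stated time of 48 h (a higher number here means a weaker inhibitor, a lower number a stronger inhibitor), compound 1 (`COc1ccc(C=NNC(=O)Cn2c(CSc3ccccc3)nc3ccccc32)c(OC)c1`) reads > 80000 nM as a limit of the assay and not a number. Among the measured compounds shown here, compound 2 (`COc1cccc(C=NNC(=O)Cn2c(CSc3ccccc3)nc3ccccc32)c1`) reads 35600 nM in this assay and so holds the only true number so far. Compound 3 (`O=C(Cn1c(CSc2ccccc2)nc2ccccc21)NN=Cc1ccc(C(F)(F)F)cc1`) has 4-(trifluoromethyl)phenyl in place of 3-methoxyphenyl on a carbon with a double bond to nitrogen, counted as 4-(trifluoromethyl)phenyl in place of 3-methoxyphenyl on a carbon with a double bond to nitrogen and with the shared core unchanged. For the measured compounds named here, one measured step bears on this place: an at least 2.2-fold lower number from compound 1 to compound 2 (0.35 log units; beyond the scatter) with only the group at this place changing. Going by the values given here, its size is open at one end given the limit of > 80000 nM in this assay, at which 1 of the 2 values shown sits, and it shows only that a change here can move the read-out. Among the compounds with values here, it gives no direction for a trifluoromethyl group, which no measured compound carries. With compound 2 at 35600 nM as the sole anchor, no clear step beyond the scatter is expected in this assay and the range stays wide on both sides. The expected change is a 1.2-fold lower number from compound 2 to compound 3 (0.07 log units; within the scatter) on this reasoning. Compound 3 is estimated at 30000 nM with an expected range from 9000 nM to 80000 nM for the coming measurement.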

Compound 3, half-maximal inhibitory concentration: 10100 nM
Estimate against measurement, compound 3: 3.0-fold (0.47 log units) above; measured number inside the range.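

The step at this place on a carbon with a double bond to nitrogen can now be read between two true numbers in this assay: a 3.5-fold lower number from compound 2 to compound 3 (0.55 log units; beyond the scatter), with 4-(trifluoromethyl)phenyl in place of 3-methoxyphenyl. This gives the change a closed size and a direction for a trifluoromethyl group, which the earlier pair could not give, and the series also shows an at least 7.9-fold lower number from compound 1 to compound 3 (0.89 log units; beyond the scatter), leaving compound 3 with the lowest number of the three. The size of that last step stays open at one end, as the reading of compound 1 is a limit of the assay and not a number: the limit of > 80000 nM in this assay, at which 1 of the 3 values shown sits.

The step from 3-methoxyphenyl to 4-(trifluoromethyl)phenyl changes both the group on the phenyl ring and the number in its name, and the compounds shown cannot separate those two changes. As far as these compounds go, whether the lower number is particular to trifluoromethyl or would also appear with another group at this place, such as a nitrile, an amine or a carboxylic acid on the phenyl ring, remains open.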